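A Chlorine Joins the Trifluoromethyl Group

A few compounds are considered here, and "the series" means these few. Any claim that something is new, unique, unknown or untested is made for them only; others in the source may bear on it.

Of the compounds shown here, two sharing one core have been measured. Compound 1 `COc1cc2cc(Oc3ccc(NC(=O)Nc4ccc(C)cc4)cc3)c(C)nc2cc1OC` carries a methyl on its outer ring, and in a functional assay on U-251 cells (Homo sapiens) for inhibition, read by sulforhodamine B assay, with a stated time of 48 h, tested at 10 uM (a higher number here means a weaker effect of the compound at the concentration tested, a lower number a stronger effect), compound 1 gives 99.9%, so at this concentration the cells are barely affected. Compound 2 `COc1cc2cc(Oc3ccc(NC(=O)Nc4ccc(C(F)(F)F)cc4)cc3)c(C)nc2cc1OC` replaces that methyl with trifluoromethyl, and in this assay compound 2 gives 15%. The single step shown, a number 84.9 percentage points lower from compound 1 to compound 2 (beyond the scatter), is therefore large, and compound 2 stands as the lower of the two numbers, well separated from compound 1.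

Compound 3 `COc1cc2cc(Oc3ccc(NC(=O)Nc4ccc(Cl)c(C(F)(F)F)c4)cc3)c(C)nc2cc1OC` is the next member. Its difference from compound 2 is 4-chloro-3-(trifluoromethyl)phenyl in place of 4-(trifluoromethyl)phenyl on an amide-type nitrogen: the trifluoromethyl stays, and a chlorine is added on the same ring. Among the compounds with values here, no measured step bears directly on adding a chlorine; the only step available concerns swapping methyl for trifluoromethyl, which is already in place in compound 2. With compound 2 already strongly active, the step expected in this assay is small, at most a modest further fall that may lie within the scatter, a number 3 percentage points lower from compound 2 to compound 3 (within the scatter). Compound 3 is thus estimated at 12%, with a likely range from 3% to 30%.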

Compound 3, a percentage reported as activity, at one concentration (the size of the read-out at that concentration, not a potency): -80.4%
For compound 3 the middle estimate is 92.4 percentage points above the measured one, outside the stated range (below it).
By their numbers in this assay, from the lowest: compound 3; then compound 2; then compound 1.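

The earlier compounds shown here might suggest that with compound 2 this outer ring on the amide-type nitrogen had little left to give, but adding one chlorine to the trifluoromethyl-bearing ring gives, in this assay, a number 95.4 percentage points lower from compound 2 to compound 3 (beyond the scatter), so a large effect remains available at this position. Compound 3 gives -80.4%, a read-out below zero, and the full change from 4-methylphenyl to 4-chloro-3-(trifluoromethyl)phenyl amounts to a number 180.3 percentage points lower from compound 1 to compound 3 (beyond the scatter), showing how strongly the result depends on this ring when the shared core stays the same. Nothing shown here explains why the added chlorine has such a large effect.

The compounds shown leave open whether the chlorine would have a similar effect without the trifluoromethyl, as in a 4-chlorophenyl group, or whether another group, such as an amine, a carboxylic acid or a methoxy, could take its place on the ring. With one cell line and one tested concentration, they also leave open how potent compound 3 is and whether its effect extends to other cells.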